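Solubility of two compounds, and an expectation for a third

This account rests on a few compounds, and the source may have more. Where it says the series, first, only, none or still open, it means among the compounds named here.

Measured in a physicochemical assay for solubility, read by spectrophotometry, in phosphate buffer, with a stated time of 18 h, at pH 7.4; a lower number here means a less soluble compound, a higher number a more soluble compound:
- compound 1 `CCc1ccc(-c2nc3c(c(C)nn3-c3ccccc3)c(-c3ccccc3I)c2C#N)cc1`: 8500 nM
- compound 2 `CCc1ccc(-c2nc3c(c(C)nn3-c3ccccc3)c(-c3ccccc3F)c2C#N)cc1`: 1700 nM

Compound 2 holds the lower of the two numbers, at 1700 nM. Compound 3 `CCc1ccc(-c2nc3c(c(C)nn3-c3ccccc3)c(-c3ccccc3C(F)(F)F)c2C#N)cc1` differs from it by trifluoromethyl in place of fluoro on an aromatic carbon, ortho to a large group. For the measured compounds named here, only one measured step bears on this change: a 5.0-fold lower number from compound 1 to compound 2 (0.70 log units; beyond the scatter), a modest step with fluoro in place of iodo on an aromatic carbon. Leaving fluoro again, a modest rise in this assay is expected, though one step is thin evidence. The expected change is a 2.4-fold higher number from compound 2 to compound 3 (0.37 log units; beyond the scatter). For compound 3 the estimate is 4000 nM, with an expected range of 1500 nM to 10000 nM.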

Compound 3, solubility: 11000 nM
For compound 3 the middle estimate is 2.8-fold (0.44 log units) below the measured one; the measured number lies above the stated range.
By their numbers in this assay, from the lowest: compound 2; then compounds 1 and 3 (each within the scatter of the next).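

In this assay, trifluoromethyl in place of fluoro on this aromatic carbon gives a 6.5-fold higher number from compound 2 to compound 3 (0.81 log units; beyond the scatter), so among these three compounds fluoro alone goes with the lower number. Trifluoromethyl and iodo cannot be told apart at this position, with a 1.3-fold higher number from compound 1 to compound 3 (0.11 log units; within the scatter). Nothing measured here accounts for this result.

On these data alone, it remains open whether an amine or a methoxy group at this position would fall with fluoro or with the other two groups. As far as these compounds go, whether the same pattern holds on a different core also remains open.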